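Working notes: from compound 3 to compound 4

This account rests on a few compounds, and the source may have more. Where it says the series, first, only, none or still open, it means among the compounds named here.

Three measured compounds share one core and differ in the group on an aromatic nitrogen. In a functional assay on HT-29 cells (Homo sapiens) for inhibition, read by luminescence and CellTiter-Glo, with a stated time of 24 h (on this read-out higher numbers stand for an effect only at larger amounts of compound and lower numbers for an effect already at smaller amounts), compound 1 `CC(C)CCn1nc(C(=O)N[C@H]2COc3ccccc3N(C)C2=S)nc1Cc1ccccc1` gives 3640 nM, compound 2 `CN1C(=S)[C@@H](NC(=O)c2nc(Cc3ccccc3)n(CCCO)n2)COc2ccccc21` gives 209 nM and compound 3 `CN1C(=S)[C@@H](NC(=O)c2nc(Cc3ccccc3)n(CCCCC#N)n2)COc2ccccc21` gives 2680 nM. Compound 3 is thus level with compound 1 within the scatter, and both lie well above compound 2.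

The next compound is compound 4 `CN1C(=S)[C@@H](NC(=O)c2nc(Cc3ccccc3)n(C3CCC3)n2)COc2ccccc21`, with cyclobutyl in place of 4-cyanobutyl on an aromatic nitrogen. Swapping one hydroxy-free chain for another gave a 1.4-fold lower number from compound 1 to compound 3 (0.13 log units; within the scatter). The large steps both involve the hydroxy chain of compound 2: a 17-fold lower number from compound 1 to compound 2 (1.24 log units; beyond the scatter) and a 13-fold higher number from compound 2 to compound 3 (1.11 log units; beyond the scatter). Cyclobutyl has no hydroxy group, so a step of that size is not expected. Among the measured compounds shown here, no measured compound carries a ring on this nitrogen, which leaves the expectation loose. In this assay the expected step is a 3.4-fold lower number from compound 3 to compound 4 (0.53 log units; beyond the scatter). For compound 4 the estimated value is 800 nM, with an expected range of 170 nM to 3500 nM.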

Compound 4, half-maximal effective concentration: 181 nM
Beside the measured number, compound 4's estimate is 4.4-fold (0.65 log units) above it; the range from low to high includes it.
By their numbers in this assay, from the lowest: compounds 4 and 2 (each within the scatter of the next); then compounds 3 and 1 (each within the scatter of the next).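

In this assay, cyclobutyl on the aromatic nitrogen gives a 15-fold lower number from compound 3 to compound 4 (1.17 log units; beyond the scatter) and a 20-fold lower number from compound 1 to compound 4 (1.30 log units; beyond the scatter) as well, so among these compounds a low number at this position does not depend on the hydroxy group of compound 2. Set against 3-hydroxypropyl, the same position shows a 1.2-fold lower number from compound 2 to compound 4 (0.06 log units; within the scatter) and thus leaves a ring of carbon only level with the hydroxy chain. Nothing measured here accounts for the difference between cyclobutyl and the two hydroxy-free chains.

On these data alone, whether the low number belongs to cyclobutyl alone or extends to other rings on this nitrogen, such as cyclopentyl or phenyl, stays open. So does the outcome for a terminal amine or carboxylic acid on a chain at this position.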